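The compounds below may be only part of what the source reports. "The series", "measured", "known", "first", "only" and "open" are said of these compounds alone.

Compound 3 `CCCc1nc(-c2ccccc2)c(CNCCCN2CCN(c3ccccc3C(F)(F)F)CC2)o1` stands lowest of the three compounds measured in an assay on HEK293 cells for inhibition of Voltage-dependent T-type calcium channel subunit alpha-1G (Homo sapiens), read by fluorescence, tested at 10 uM (on this read-out higher numbers stand for more inhibition at the one concentration tested (going by the name of the read-out) and lower numbers for less inhibition), where it gives 45%. Compound 1 `CCCc1nc(-c2ccccc2)c(CNCCCN2CCN(c3ccccc3Cl)CC2)o1` gives 64.7% in this assay, and compound 2 `CCCc1nc(-c2ccccc2)c(CNCCCN2CCN(c3cccc(Cl)c3)CC2)o1` gives 65.9%; the step of a number 1.2 percentage points higher from compound 1 to compound 2 (within the scatter) shows that moving the chloro between these two positions made no difference that can be trusted. The steps of a number 19.7 percentage points lower from compound 1 to compound 3 (beyond the scatter) and a number 20.9 percentage points lower from compound 2 to compound 3 (beyond the scatter) are both beyond the scatter and place compound 3 clearly below the other two.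

Compound 4 `CCCc1nc(-c2ccccc2)c(CNCCCN2CCN(c3ccccc3)CC2)o1` differs from compound 3 by hydrogen in place of trifluoromethyl on an aromatic carbon. Among the measured compounds shown here, no measured step removes a group at this place outright, so the bearing on it is indirect: the only step that touches the same aromatic carbon is a number 19.7 percentage points lower from compound 1 to compound 3 (beyond the scatter), a modest fall when chloro became trifluoromethyl. Losing the trifluoromethyl is therefore expected to bring compound 4 back toward the level of compound 1, though with wide uncertainty. The step of a number 13 percentage points higher from compound 3 to compound 4 (beyond the scatter) is the estimated change, and compound 4 is expected to give 58% in this assay, within a range from 40% to 75%.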

Compound 4, a percentage reported as inhibition, at one concentration (the size of the read-out at that concentration, not a potency): 43.7%
Estimate against measurement, compound 4: 14.3 percentage points above; the range from low to high includes it.
By their numbers in this assay, from the lowest: compounds 4 and 3 (each within the scatter of the next); then compounds 1 and 2 (each within the scatter of the next).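

In this assay the step of a number 1.3 percentage points lower from compound 3 to compound 4 (within the scatter) shows that trifluoromethyl and hydrogen cannot be told apart on this aromatic carbon, so the lower number of compound 3 does not mark a loss that removing the group reverses. The steps of a number 21 percentage points lower from compound 1 to compound 4 (beyond the scatter) and a number 22.2 percentage points lower from compound 2 to compound 4 (beyond the scatter) show instead that hydrogen in place of chloro falls beyond the scatter in both chlorophenyl compounds, so among these four compounds the higher level goes with chloro alone and trifluoromethyl does not share it. Nothing at hand explains why chloro and trifluoromethyl part here.

The compounds shown leave open whether fluoro, methyl or methoxy on this ring would stand with chloro or with hydrogen. They also leave open whether a second chloro on the same ring would raise the number further.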